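Cyclopentyl for cyclohexyl on the amide nitrogen of compound 2

The source may hold more compounds than are shown below. What is called first, only, known or untested is meant among the compounds shown, and "the series" means these compounds.

Measured so far:
compound 1 `O=C(NCCCN1CCN(CCCNC(=O)c2cc3ccccc3oc2=O)CC1)c1cc2ccccc2oc1=O`, 15%
compound 2 `COc1cccc2cc(C(=O)NC3CCCCC3)c(=N)oc12`, 16%

In an assay on HeLa cells for displacement of a labelled ligand from adenosine receptor A3 (Homo sapiens), read by scintillation counting, with a stated time of 180 min, tested at 10 uM (a higher number here means more inhibition at the concentration tested (going by the name of the read-out), a lower number less inhibition), compound 1 gives 15%. In this assay compound 2 gives 16%, the higher of the two numbers, though the gap to compound 1 lies within the scatter, so the two read as equivalent. Among the measured compounds shown here, no step between compounds differing in one place is available.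

Compound 3 `COc1cccc2cc(C(=O)NC3CCCC3)c(=N)oc12` is the next compound, not yet measured in this assay. It differs from compound 2 by cyclopentyl in place of cyclohexyl on an amide-type nitrogen. Both values seen so far sit in the same low region, and the change is a small one in ring size on the amide nitrogen, so no step beyond the scatter is expected; the estimated step is a number 1 percentage points lower from compound 2 to compound 3 (within the scatter). For compound 3 the estimate in this assay is 15%, within 4% to 27%.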

Compound 3, a percentage reported as inhibition, at one concentration (the size of the read-out at that concentration, not a potency): 20%
Compound 3: middle estimate off by 5 percentage points, on the low side, and the stated range covers the measured number.
By their numbers in this assay, from the lowest: compounds 1, 2 and 3 (each within the scatter of the next).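

In this assay, among the compounds shown here, cyclopentyl in place of cyclohexyl on the amide-type nitrogen gives a number 4 percentage points higher from compound 2 to compound 3 (within the scatter), the first comparison of compounds that differ in one place. The two ring sizes therefore cannot be told apart here, and the read-out of this pair gives no sign that the size of the carbon ring on this nitrogen matters between five-membered and six-membered. Nothing at hand explains the result or bears on it.

Still open, as far as these compounds go, is whether any group on this nitrogen moves the number beyond the scatter, for instance a benzyl group, an open isopropyl group or a chain ending in an amine. Also open, from the compounds shown here alone, is what a hydroxyl in place of the methoxy on the shared core would do.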